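The source may report more compounds than this note shows. Statements on the series, on what has been measured and on what is new or still open speak of the compounds shown alone.

Measured so far in an assay on HepG2 cells for agonist activity at nuclear receptor subfamily 1 group I member 3 (Homo sapiens), read by a luciferase reporter, with a stated time of 23 h; a lower number here means that less compound is needed, a higher number that more compound is needed for the effect:
Compound 1, `N#Cc1ccc(-c2nc3sccn3c2/C=N/OCc2ccc(Cl)c(Cl)c2)cc1`, gives 3400 nM.
Compound 2, `FC(F)(F)c1ccc(-c2nc3sccn3c2/C=N/OCc2ccc(Cl)c(Cl)c2)cc1`, gives 880 nM.

Among the compounds with values here, compound 2 stands lowest of these two numbers in this assay; its only neighbour is compound 1, and the step of a 3.9-fold lower number from compound 1 to compound 2 (0.59 log units; beyond the scatter) lies beyond the scatter. Compound 3, `Clc1ccc(CO/N=C/c2c(-c3ccc(C4CCCCC4)cc3)nc3sccn23)cc1Cl`, has not been measured. It differs from compound 2 by cyclohexyl in place of trifluoromethyl on an aromatic carbon. Within the data shown here, the one measured step that bears on this change is the exchange at the same aromatic carbon, a 3.9-fold lower number from compound 1 to compound 2 (0.59 log units; beyond the scatter), a modest step; no measured compound carries a cyclohexyl there, so the expectation rests on that single step and on the absence of any contrary one. For compound 3 a small step downward, or none beyond the scatter, is expected in this assay, a 1.8-fold lower number from compound 2 to compound 3 (0.25 log units; within the scatter). The estimate for compound 3 in this assay is 500 nM, with a range from 120 nM to 2000 nM.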

Compound 3, half-maximal effective concentration: > 100000 nM
Compound 3 ended at the assay's limit; the forecaster's own chance of this, stated with the estimate: 10%; middle value at least 200-fold (2.30 log units) from the limit.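

In this assay the reading of compound 3 is a limit of the assay and not a number: the limit of > 100000 nM in this assay, at which 1 of the 3 values shown sits. Even so, changes at this aromatic carbon are not confined to modest steps: cyclohexyl in place of trifluoromethyl gives an at least 110-fold higher number from compound 2 to compound 3 (2.05 log units; beyond the scatter), and cyclohexyl in place of cyano gives an at least 29-fold higher number from compound 1 to compound 3 (1.46 log units; beyond the scatter). The exchange of nitrile for trifluoromethyl had moved the number only modestly, whereas cyclohexyl at the same place carries the reading to the limit of the assay, so that earlier step gave no guide to this one.

The compounds shown do not tell whether this result belongs to the non-aromatic ring itself or to any group of as many heavy atoms. As far as these compounds go, how a tert-butyl group, a methoxy group or a piperidine ring at the same carbon would read remains open.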